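Three nitrobenzyl and aminobenzyl amines, all at the assay limit

The compounds below may be only part of what the source reports. "The series", "measured", "known", "first", "only" and "open" are said of these compounds alone.

Measured so far:
- Compound 1 `O=C1NC(=O)c2c(NCc3ccccc3[N+](=O)[O-])cccc21`: in an assay for inhibition of Indoleamine 2,3-dioxygenase 1 (Homo sapiens), with stated times of 10 min and 60 min (a lower number here means a stronger inhibitor, a higher number a weaker inhibitor), compound 1 gives only the limit > 100000 nM.
- Compound 2 `NCCn1ncc2c(NCc3ccccc3[N+](=O)[O-])cc(C(F)(F)F)cc21`: in this assay compound 2 gives only the limit > 100000 nM.
- Compound 3 `Nc1cccc(CNc2cc(C(F)(F)F)cc3[nH]ncc23)c1`: in this assay compound 3 gives only the limit > 100000 nM.

Compound 2 therefore stands nowhere distinct in this assay: its value is a limit, not a number, and it shares the limit of > 100000 nM in this assay, at which 3 of the 3 values shown sit, with the two other measured compounds. Among the compounds with values here, no pair of measured compounds differs in one place, so no measured step exists to lean on.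

Compound 4 `O=[N+]([O-])c1ccccc1CNc1cc(C(F)(F)F)cc2[nH]ncc12` is the next compound to go into this assay. Relative to compound 2 the change is hydrogen in place of 2-aminoethyl on an aromatic nitrogen, in words: hydrogen in place of 2-aminoethyl on an aromatic nitrogen.

Without any measured step in the series, no direction can be drawn from the data; the working expectation is a step of no size beyond the scatter, a number no higher from compound 2 to compound 4 (the limit leaves the size open), with the result most likely again reported as a limit. Compound 4 is accordingly estimated at 100000 nM, within 20000 nM to 300000 nM.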

Compound 4, half-maximal inhibitory concentration: 14000 nM
For compound 4 the middle estimate is 7.1-fold (0.85 log units) above the measured one, and the stated range ends above it.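

In this assay, within the data shown here, hydrogen in place of 2-aminoethyl on an aromatic nitrogen gives an at least 7.1-fold lower number from compound 2 to compound 4 (0.85 log units; beyond the scatter), so activity at this position responds to the substituent, which the earlier compounds could not show. Among these compounds, compound 4 gives 14000 nM, the only value that is a number rather than a limit. The true size of the step stays unknown because the value of compound 2 is a limit and not a number: the limit of > 100000 nM in this assay, at which 3 of the 4 values shown sit.

Going by these compounds, it remains open whether the hydrogen on this nitrogen matters in itself or whether the 2-aminoethyl chain simply costs activity, a question that a methyl, a 2-hydroxyethyl or a longer chain ending in a carboxylic acid on the same nitrogen would help settle. Also open, on these data alone, is what the nitro group contributes in compound 4, which a nitrile in its place would test.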